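Adding a Second Chloro: From Compound 2 to Compound 3

The compounds below may be only part of what the source reports. "The series", "measured", "known", "first", "only" and "open" are said of these compounds alone.

Of the compounds shown here, two sharing one core have been tested in a functional assay on Bel-7402 cells (Homo sapiens) for cytotoxicity, read by MTT assay; on this read-out lower numbers stand for stronger inhibition and higher numbers for weaker inhibition. Compound 1 `Cc1nc(Nc2ccc(Cl)c(Cl)c2)sc1C(=O)/C=C/c1ccc(Cl)cc1` carries a (3,4-dichlorophenyl)amino group. In this assay compound 1 gives only a limit, > 25000 nM, not a number. Compound 2 `COc1cccc(/C=C/C(=O)c2sc(Nc3cccc(Cl)c3)nc2C)c1` carries a (3-chlorophenyl)amino group instead. In this assay compound 2 likewise gives only a limit, > 25000 nM. Among the measured compounds shown here, compound 2 therefore stands where every value so far stands, namely at the limit of > 25000 nM in this assay, at which 2 of the 2 values shown sit. Compound 3 `COc1cccc(/C=C/C(=O)c2sc(Nc3ccc(Cl)c(Cl)c3)nc2C)c1` is the next step from compound 2: chloro in place of hydrogen on an aromatic carbon. This change gives compound 3 the same (3,4-dichlorophenyl)amino group that compound 1 carries. Both measured values sit at the limit of > 25000 nM in this assay, at which 2 of the 2 values shown sit. The step that the limit leaves unreadable from compound 2 to compound 3 is therefore expected to be none beyond the usual scatter. Compound 3 is expected to give about 40000 nM, within a range of 15000 nM to 120000 nM, most likely reported again only as a limit.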

Compound 3, half-maximal inhibitory concentration: > 25000 nM
Compound 3 ended at the assay's limit; the forecaster's own chance of this, stated with the estimate: 80%; the middle value lies beyond the limit too.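

Among the compounds shown here, compound 1, compound 2 and compound 3 all give only a limit in this assay, so no step between them can be read: the limit of > 25000 nM in this assay, at which 3 of the 3 values shown sit. The compounds shown leave open whether the added chloro, or 3-methoxyphenyl in place of 4-chlorophenyl, changes cytotoxicity at all.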